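Piperidine substituent change in an anilinoquinazoline antiproliferative series

The source may hold more compounds than are shown below. What is called first, only, known or untested is meant among the compounds shown, and "the series" means these compounds.

Measured so far:
compound 1 `COc1cc2c(Nc3ccc(C#N)cc3)ncnc2cc1OCCCN(C)Cc1ccccc1` — > 100000 nM
compound 2 `COc1cc2c(Nc3ccc(C#N)cc3)ncnc2cc1OCCCN1CCC(O)CC1` — 74900 nM

In a functional assay on DU-145 cells (Homo sapiens) for antiproliferative activity, read by MTT assay, with a stated time of 72 h (on this read-out higher numbers stand for weaker inhibition and lower numbers for stronger inhibition), compound 1 reaches only the limit > 100000 nM, a limit rather than a number. Compound 2 gives 74900 nM in this assay, the only number shown in the set. The step of an at least 1.3-fold lower number from compound 1 to compound 2 (0.12 log units; that floor lies within the scatter) sits at the floor of what the limit allows and within the scatter (the limit of > 100000 nM in this assay, at which 1 of the 2 values shown sits). Compound 3 `CCOC(=O)C1CCN(CCCOc2cc3ncnc(Nc4ccc(C#N)cc4)c3cc2OC)CC1` carries ethoxycarbonyl in place of hydroxy on a saturated ring carbon. Among the measured compounds shown here, no measured step touches this position; the one step available, an at least 1.3-fold lower number from compound 1 to compound 2 (0.12 log units; that floor lies within the scatter), is itself inconclusive, so the expected step of a 1.1-fold lower number from compound 2 to compound 3 (0.03 log units; within the scatter) lies within the scatter. Compound 3 is estimated at 70000 nM in this assay, ranging from 25000 nM to 200000 nM.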

Compound 3, half-maximal inhibitory concentration: 52300 nM
The estimate for compound 3 lay 1.3-fold (0.13 log units) above the measured number; low and high end bracket the measured number.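

In this assay, ethoxycarbonyl in place of hydroxy on this saturated ring carbon gives a 1.4-fold lower number from compound 2 to compound 3 (0.16 log units; within the scatter), so replacing hydroxy with this larger group, which has no hydrogen-bond donor, leaves the number within the scatter. Compound 1 stands at a limit, not a number: the limit of > 100000 nM in this assay, at which 1 of the 3 values shown sits.

The step of an at least 1.9-fold lower number from compound 1 to compound 3 (0.28 log units; that floor lies within the scatter) therefore cannot be read as a size.

Open, from the compounds shown here alone, is whether a carboxylic acid or a primary amine on this ring carbon would move the number beyond the scatter. Going by these compounds, a longer chain to the ring nitrogen is equally open.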